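A few compounds are considered here, and "the series" means these few. Any claim that something is new, unique, unknown or untested is made for them only; others in the source may bear on it.

Working notes on the series. Compound 1 `Cc1cc(NNC(=O)Nc2cc(Cl)nc(Cl)c2)ncc1C#N` carries a nitrile on an aromatic carbon of its core; in a functional assay on CHO cells for antagonist activity at sphingosine 1-phosphate receptor 2 (Homo sapiens), read by fluorescence and calcium flux, with a stated time of 3 min (a lower number here means a stronger inhibitor, a higher number a weaker inhibitor), compound 1 gives 6000 nM. Compound 3 `Cc1cc(NNC(=O)Nc2cc(Cl)nc(Cl)c2)ncc1-c1ccn(C)n1` carries a 1-methyl-1H-pyrazol-3-yl at that carbon in place of the nitrile and in this assay compound 3 gives 4000 nM; the step is a 1.5-fold lower number from compound 1 to compound 3 (0.18 log units; within the scatter). Compound 2 `Cc1cc(CO)nc(NNC(=O)Nc2cc(Cl)nc(Cl)c2)c1` carries a hydroxymethyl at another aromatic carbon. In this assay compound 2 gives only a limit, > 6600 nM. This is the limit of > 6600 nM in this assay, at which 1 of the 3 values shown sits. Compound 2 thus stands at the weak end of the numbers shown, without a number of its own.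

Compound 4 `Cc1cc(NNC(=O)Nc2cc(Cl)nc(Cl)c2)nc(C(=O)N(C)C2CC2)c1` differs from compound 2 by cyclopropyl(methyl)carbamoyl in place of hydroxymethyl on an aromatic carbon. Among the measured compounds shown here, no measured step touches this substituent. For the measured compounds named here, the single measured step, a 1.5-fold lower number from compound 1 to compound 3 (0.18 log units; within the scatter), concerns a different carbon of the core and sits within the scatter, and it offers no direction for the change to compound 4. Going by these compounds, with compound 2 at a limit, both directions remain open for this assay. Compound 4 is expected at 5000 nM, within a range from 1500 nM to 20000 nM. The expected step is an at least 1.3-fold lower number from compound 2 to compound 4 (0.12 log units; that floor lies within the scatter), with a real chance that this assay again reports only a limit.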

Compound 4, half-maximal inhibitory concentration: > 20000 nM
Compound 4 ended at the assay's limit; the forecaster's own chance of this, stated with the estimate: 45%; middle value at least 4.0-fold (0.60 log units) away from the limit.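

In this assay compound 4 gives only a limit, > 20000 nM. Among the compounds shown here, compound 2 also gives only a limit, > 6600 nM, so no step between compound 2 and compound 4 can be read. The compounds shown leave open whether hydroxymethyl or cyclopropyl(methyl)carbamoyl on that aromatic carbon gives the lower number in this assay.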